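Thiophene to Furan: What Permeability Change to Expect

A few compounds are considered here, and "the series" means these few. Any claim that something is new, unique, unknown or untested is made for them only; others in the source may bear on it.

Measured compounds in an ADME assay on Caco-2 cells (Homo sapiens) for permeability, in the apical to basolateral direction; a higher number here means that the compound crosses the layer faster, a lower number that the compound crosses the layer more slowly:
- compound 1 `Cn1nc2c(=O)n(CC3(O)CCN(Cc4ccc(-c5ccco5)cc4Cl)CC3)cnc2c1-c1ccc(C2(N)CC2)cc1`: 1.99 10^-6 cm/s
- compound 2 `Cn1nc2c(=O)n(CC3(O)CCN(Cc4ccc(-c5cccs5)cc4Cl)CC3)cnc2c1-c1ccc(CN)cc1`: 0.8 10^-6 cm/s
- compound 3 `Cn1nc2c(=O)n(CC3(O)CCN(Cc4ccc(-c5ccc(C(=O)O)o5)cc4Cl)CC3)cnc2c1-c1ccc(CN)cc1`: 0.33 10^-6 cm/s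

Compound 2 stands second highest of the three numbers. Its nearest neighbour is compound 3, reached by the step of a 2.4-fold lower number from compound 2 to compound 3 (0.38 log units; beyond the scatter). Among the compounds with values here, compound 1 lies further away; its value is higher than that of compound 2, though no single-point step between these two is available, since they differ in more than one place.

Compound 4 `Cn1nc2c(=O)n(CC3(O)CCN(Cc4ccc(-c5ccco5)cc4Cl)CC3)cnc2c1-c1ccc(CN)cc1` differs from compound 2 in one place: furan-2-yl in place of thiophen-2-yl on an aromatic carbon.

Within the data shown here, only one measured step touches the same position, and it is the step from compound 2 to compound 3, where a furan ring enters together with a carboxylic acid. That step is modest and downward, but the acid makes it an imperfect guide. Compound 1 carries the same furan-2-yl as compound 4 yet differs elsewhere, so its higher number is only weak support. The expectation for compound 4 in this assay is therefore a step no larger than the scatter, if anything slightly upward, expressed as a 1.3-fold higher number from compound 2 to compound 4 (0.10 log units; within the scatter). Compound 4 is estimated at 1 10^-6 cm/s, within a range from 0.45 10^-6 cm/s to 2.2 10^-6 cm/s.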

Compound 4, apparent permeability: 0.92 10^-6 cm/s
Compound 4: middle estimate off by 1.1-fold (0.04 log units), on the high side, and the stated range covers the measured number.
By their numbers in this assay, from the lowest: compound 3; then compounds 2 and 4 (each within the scatter of the next); then compound 1.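

In this assay, within the data shown here, the change of thiophen-2-yl to furan-2-yl on the aromatic carbon para to a large group gives a 1.2-fold higher number from compound 2 to compound 4 (0.06 log units; within the scatter) and so leaves the two rings indistinguishable here, which the earlier compounds could not show, since the furan ring of compound 3 came with a carboxy group attached. Removing that carboxy group gives a 2.8-fold higher number from compound 3 to compound 4 (0.45 log units; beyond the scatter) and places compound 4 alongside compound 2, so among these compounds the lower number of compound 3 appears only where the carboxy group is present. Compound 1 shares furan-2-yl with compound 4, and a 2.2-fold lower number from compound 1 to compound 4 (0.34 log units; beyond the scatter) comes with aminomethyl in place of 1-aminocyclopropyl, so the higher number of compound 1 goes with that other position and not with the furan ring.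

Nothing shown here gives a reason for any of these steps. Still open, on these data alone, is whether the match between the two rings holds with 1-aminocyclopropyl at the other position, and whether a pyridine ring, or a furan ring carrying a methyl ester or an amine instead of the carboxy group, would stay with compound 4 or fall toward compound 3.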